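This account rests on a few compounds, and the source may have more. Where it says the series, first, only, none or still open, it means among the compounds named here.

Measured so far in an in vitro ADME assay on the whole organism (small intestine) for pharmacokinetics, with Rattus norvegicus as the target; on this read-out higher numbers stand for a longer-lived compound and lower numbers for a shorter-lived compound:

- compound 1 `C=CCN(CCCC(=O)O)C(=O)/C(C)=C/c1ccc(C(=O)Oc2ccc(C(=N)N)cc2)cc1`: 0.917 h
- compound 2 `CCOC(=O)CN(Cc1ccccc1)C(=O)/C(C)=C/c1ccc(C(=O)Oc2ccc(C(=N)N)cc2)cc1`: 0.733 h
- compound 3 `C/C(=C\c1ccc(C(=O)Oc2ccc(C(=N)N)cc2)cc1)C(=O)N(CC(=O)O)C1CCCC1`: 0.7 h

In this assay compound 3 gives 0.7 h, a number that cannot be told apart from those of the other two compounds, since all three lie within the usual scatter of repeated measurements. The next compound to be tested is compound 4 `C/C(=C\c1ccc(C(=O)Oc2ccc(C(=N)N)cc2)cc1)C(=O)N(CC(=O)O)Cc1ccccc1`, which has benzyl in place of cyclopentyl on an amide-type nitrogen.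

Within the data shown here, only one measured step bears on this change directly. It is a 1.3-fold lower number from compound 1 to compound 3 (0.12 log units; within the scatter), the step that brought in the cyclopentyl now leaving, and it stayed within the scatter. Benzyl itself appears in compound 2 at 0.733 h, but that compound also differs elsewhere, so no measured pair isolates this swap. The data therefore give no reason to expect a real shift in this assay. The estimate means a 1.1-fold higher number from compound 3 to compound 4 (0.03 log units; within the scatter), which is expected to stay within the scatter. For compound 4 the expected value is 0.75 h, with an estimated range of 0.4 h to 1.4 h.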

Compound 4, half-life: 0.833 h
The estimate for compound 4 lay 1.1-fold (0.05 log units) below the measured number; measured number inside the range.
By their numbers in this assay, from the lowest: compounds 3, 2, 4 and 1 (each within the scatter of the next).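

At this amide-type nitrogen, with the carboxymethyl group kept in place, the five-membered non-aromatic cyclopentyl ring can give way to the aromatic benzyl group with only a 1.2-fold higher number from compound 3 to compound 4 (0.08 log units; within the scatter) in this assay and no shift beyond the scatter. Among these compounds, the new compound also gives the first pair that isolates the ester: replacing ethyl with hydrogen, which leaves a carboxylic acid, gives a 1.1-fold higher number from compound 2 to compound 4 (0.06 log units; within the scatter) and again stays within the scatter. No measurement shown here gives a cause for either small step.

The compounds shown leave open whether benzyl would give a similar half-life alongside the longer carboxypropyl chain of compound 1. They also leave open whether an amine or a cyclohexyl group on this nitrogen would move the number beyond the scatter.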